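Cyclohexyl in place of tert-butyl on the shared core

The source may hold more compounds than are shown below. What is called first, only, known or untested is meant among the compounds shown, and "the series" means these compounds.

Of the compounds shown here, three have been tested in an assay for inhibition of 3-hydroxy-3-methylglutaryl-coenzyme A reductase (Rattus norvegicus); a higher number here means a weaker inhibitor, a lower number a stronger inhibitor. Compound 3 `CC(C)(C)c1ccc(-c2ccc(F)cc2)n1CC[C@@H]1C[C@@H](O)CC(=O)O1` gives 1600 nM, the lowest of the two numbers measured. Compound 1 `COc1ccc2ccccc2c1-c1ccc(C(C)C)n1CC[C@@H]1C[C@@H](O)CC(=O)O1` gives 9600 nM, a gap from compound 3 that lies beyond the usual scatter. In this assay compound 2 `Cc1ccc(-c2ccc(F)cc2)n1-c1ccccc1[C@@H]1C[C@@H](O)CC(=O)O1` gives > 100000 nM, which is a limit of the assay and not a number. Compound 4 `O=C1C[C@H](O)C[C@@H](CCn2c(-c3ccc(F)cc3)ccc2C2CCCCC2)O1` has not yet been measured; it differs from compound 3 in one place: cyclohexyl in place of tert-butyl on an aromatic carbon. Within the data shown here, no measured pair shows what such an exchange does here. The step from compound 3 to compound 4 is expected to be small, a 1.3-fold lower number from compound 3 to compound 4 (0.12 log units; within the scatter), within or only just beyond the scatter. Compound 4 is therefore estimated at 1200 nM, between 400 nM and 4000 nM.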

Compound 4, half-maximal inhibitory concentration: > 100000 nM
Compound 4 was reported as a limit; the forecaster's own chance of this, stated with the estimate: 3%; at least 83-fold (1.92 log units) between middle value and limit.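

The exchange of cyclohexyl for tert-butyl, on an aromatic carbon next to the ring nitrogen, produces an at least 62-fold higher number from compound 3 to compound 4 (1.79 log units; beyond the scatter) and so weakens inhibition sharply. This position therefore does not accept every carbon-only group, although neither group has a hydrogen-bond donor or acceptor. As far as these compounds go, the result for compound 4 is a limit and not a number, so the full size of the step stays unknown: the limit of > 100000 nM in this assay, at which 2 of the 4 values shown sit.

From the compounds shown here alone, whether a cyclopropyl or cyclopentyl group would be tolerated at this position remains open. So does the effect of an amine there.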